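A few compounds are considered here, and "the series" means these few. Any claim that something is new, unique, unknown or untested is made for them only; others in the source may bear on it.

In a functional assay on DU-145 cells (Homo sapiens) for inhibition, read by trypan blue exclusion, with a stated time of 96 h (a higher number here means a weaker inhibitor of growth, a lower number a stronger inhibitor of growth), compound 1 `O=C(/C(=C\c1ccc(Cl)cc1Cl)S(=O)(=O)c1ccc(Br)cc1)c1ccc(Cl)cc1` gives 50000 nM, compound 2 `CCOc1cc(/C=C(\C(=O)c2ccc(Cl)cc2)S(=O)(=O)Cc2ccc(Cl)cc2)ccc1O` gives 10000 nM, and compound 3 `COc1ccccc1/C=C(\C(=O)c1ccc(Cl)cc1)S(=O)(=O)Cc1ccc(Cl)cc1` gives 25000 nM. Compound 3 therefore stands within the scatter of compound 1 but apart from compound 2, as shown by the step of a 2.5-fold higher number from compound 2 to compound 3 (0.40 log units; beyond the scatter).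

Compound 4 `COc1ccccc1/C=C(\C(=O)c1ccc(Cl)cc1)S(=O)(=O)c1ccc(Br)cc1` differs from compound 3 on a sulfonyl sulfur, with 4-bromophenyl in place of 4-chlorobenzyl on a sulfonyl sulfur. Among the compounds with values here, the only measured step, a 2.5-fold higher number from compound 2 to compound 3 (0.40 log units; beyond the scatter), is modest and lies at another place, so it says nothing directly about this exchange. Compound 1 also carries 4-bromophenyl on a sulfonyl sulfur and gives 50000 nM, but it differs from compound 4 elsewhere as well. Its value lies within the scatter of the value of compound 3, so no step beyond the scatter is expected in this assay, and the data set no firm direction. The expected step is a 1.2-fold higher number from compound 3 to compound 4 (0.08 log units; within the scatter). For compound 4 the estimated value is 30000 nM, with an expected range of 12000 nM to 70000 nM.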

Compound 4, concentration for 50% growth inhibition: 10000 nM
Estimate against measurement, compound 4: 3.0-fold (0.48 log units) above, and the stated range ends above it.
By their numbers in this assay, from the lowest: compounds 2 and 4 (each within the scatter of the next); then compounds 3 and 1 (each within the scatter of the next).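

Within the data shown here, on the sulfonyl sulfur, 4-bromophenyl in place of 4-chlorobenzyl gives a 2.5-fold lower number from compound 3 to compound 4 (0.40 log units; beyond the scatter) in this assay, a modest step that is the first reading of any change at this place and shows that this place can move the number beyond the scatter. With 4-bromophenyl held on the sulfonyl sulfur, 2-methoxyphenyl in place of 2,4-dichlorophenyl gives a 5.0-fold lower number from compound 1 to compound 4 (0.70 log units; beyond the scatter), so the double-bonded chain carbon also responds to a change of its aryl group, again modestly. No measurement at hand accounts for either step.

The compounds shown leave open whether the step on the sulfonyl sulfur follows the halogen or the benzyl chain, which 4-chlorophenyl or 4-bromobenzyl there would separate. They also leave open how an amine or a carboxylic acid would fare on that sulfur's aryl group, and whether the step holds with 3-ethoxy-4-hydroxyphenyl on the double-bonded chain carbon.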